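Phenyl in Place of Cyclohexylamino on a Fused Core

A few compounds are considered here, and "the series" means these few. Any claim that something is new, unique, unknown or untested is made for them only; others in the source may bear on it.

Compound 1 `COc1cc(N2CCN(S(C)(=O)=O)CC2)ccc1Nc1ncc2cccc(NC3CCCCC3)c2n1`: 810 nM
Compound 2 `COc1cc(N2CCN(S(C)(=O)=O)CC2)ccc1Nc1ncc(C)c(NC2CCCCC2)n1`: 1500 nM
Compound 3 `COc1cc(N2CCN(S(C)(=O)=O)CC2)ccc1Nc1nccc(N(C)C2CCCCC2)n1`: 2000 nM

In a functional assay on HCT-116 cells (Homo sapiens) for cytotoxicity (on this read-out lower numbers stand for stronger inhibition and higher numbers for weaker inhibition), compound 1 gives 810 nM, the lowest of the three numbers. Its gap to compound 2, which gives 1500 nM, lies within the scatter, so the two cannot be ordered; compound 3, which gives 2000 nM, stands beyond the scatter from compound 1.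

Compound 4 `COc1cc(N2CCN(S(C)(=O)=O)CC2)ccc1Nc1ncc2cccc(-c3ccccc3)c2n1` is not yet measured. It differs from compound 1 in one place: phenyl in place of cyclohexylamino on an aromatic carbon. Among the measured compounds shown here, no measured pair among the three compounds shows this change, so the expectation rests on the value of compound 1 alone. The step from compound 1 to compound 4 is expected to be small, toward a higher number, and probably within the scatter, as a 1.9-fold higher number from compound 1 to compound 4 (0.27 log units; within the scatter). Compound 4 is therefore estimated at 1500 nM, with a range from 400 nM to 6000 nM.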

Compound 4, half-maximal inhibitory concentration: 1740 nM
Beside the measured number, compound 4's estimate is 1.2-fold (0.06 log units) below it; the measured number falls inside the stated range.
By their numbers in this assay, from the lowest: compounds 1, 2, 4 and 3 (each within the scatter of the next, the first and the last beyond it).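

In this assay, among the compounds shown here, this aromatic carbon of the shared core carries a change for the first time, and phenyl in place of cyclohexylamino gives a 2.1-fold higher number from compound 1 to compound 4 (0.33 log units; beyond the scatter). The step is modest: although the hydrogen-bond donor and acceptor of cyclohexylamino leave and an aromatic ring replaces a non-aromatic one, compound 4 still gives 1740 nM, so a nitrogen link at this position is not required for a value in this range. Nothing available explains the direction or size of this step.

The nitrogen link and the ring change together here, so the compounds shown cannot separate their contributions. Anilino, which keeps the nitrogen with an aromatic ring, and cyclohexyl, attached directly without the nitrogen, would pull the two apart.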